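The compounds below may be only part of what the source reports. "The series", "measured", "known", "first", "only" and "open" are said of these compounds alone.

Compound 1 `CCCCCCCCOP(=O)(O)OCCSC(=S)N1CCCC1` gives 47100 nM in a functional assay on DU-145 cells (Homo sapiens) for inhibition, read by MTT assay, with stated times of 18 h and 4 h; a higher number here means a weaker inhibitor, a lower number a stronger inhibitor.
Compound 2 `CCCCCCCCOP(=O)(O)OCCSC(=S)N1CCCCCC1` gives 59100 nM in this assay.
Compound 3 `CCCCCCOP(=O)(O)OCCSC(=S)N1CCCCCC1` gives 77400 nM in this assay.

All three compounds share a common skeleton and differ in only one place at a time. Compound 1 is obtained from compound 2 by the change (pyrrolidin-1-yl in place of azepan-1-yl on a thiocarbonyl carbon), and this gave a 1.3-fold lower number from compound 2 to compound 1 (0.10 log units; within the scatter). Compound 3 is obtained from compound 2 by the change (hydrogen in place of ethyl on a saturated chain carbon, six bonds along the chain from an oxygen on an unsaturated carbon), and this gave a 1.3-fold higher number from compound 2 to compound 3 (0.12 log units; within the scatter). Both steps stay inside the usual scatter of repeated measurements, so none of the three compounds can be set apart from the others on the strength of these numbers alone.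

Compound 4 `CCCCCCOP(=O)(O)OCCSC(=S)N1CCCC1` has not yet been measured in this assay. It differs from compound 3 by pyrrolidin-1-yl in place of azepan-1-yl on a thiocarbonyl carbon. Going by the values given here, this is the same change as the one from compound 2 to compound 1, made at the same place on the thiocarbonyl carbon whose other neighbours are sulfur. The cores on which the change is made differ from each other by hydrogen in place of ethyl on a saturated chain carbon, six bonds along the chain from an oxygen on an unsaturated carbon.

The single earlier occurrence of this change, a 1.3-fold lower number from compound 2 to compound 1 (0.10 log units; within the scatter), suggests a similarly small step is to be expected from compound 3 to compound 4, estimated as a 1.3-fold lower number from compound 3 to compound 4 (0.11 log units; within the scatter). Among the compounds with values here, because the one step seen, a 1.3-fold lower number from compound 2 to compound 1 (0.10 log units; within the scatter), is within the scatter, the expectation for compound 4 rests on little and is held loosely. Compound 4 is therefore expected to give about 60000 nM in this assay, with a plausible range from 30000 nM to 120000 nM.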

Compound 4, half-maximal inhibitory concentration: > 100000 nM
Compound 4: only a limit was reported (the forecaster's own chance of this, stated with the estimate: 5%); at least 1.6-fold (0.22 log units) between middle value and limit.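

In this assay compound 4 gives > 100000 nM, which is a limit of the assay and not a measured number. Putting pyrrolidin-1-yl in place of azepan-1-yl gives an at least 1.2-fold higher number from compound 3 to compound 4 (0.11 log units; that floor lies within the scatter), so this does not show whether the change behaves the same way on the core of compound 3 as it did on the core of compound 2: the same change on two cores in this assay, a 1.3-fold lower number (0.10 log units; within the scatter) from compound 2 to compound 1 and an at least 1.2-fold higher number (0.11 log units; that floor lies within the scatter) from compound 3 to compound 4; the limit leaves it open whether they differ. Hydrogen in place of ethyl on the saturated chain gives an at least 2.1-fold higher number from compound 1 to compound 4 (0.32 log units; beyond the scatter), which shows a real step between the two pyrrolidin-1-yl compounds but does not show that the chain matters more there than between the two azepan-1-yl compounds: the same change on two cores in this assay, a 1.3-fold higher number (0.12 log units; within the scatter) from compound 2 to compound 3 and an at least 2.1-fold higher number (0.32 log units; beyond the scatter) from compound 1 to compound 4; the limit leaves it open whether they differ.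

As far as these compounds go, the true size of both new steps stays open as long as compound 4 is known only through its limit, so these four compounds support no rule for carrying either change from one core to another. From the compounds shown here alone, it also remains open how a piperidin-1-yl or morpholin-4-yl group on the thiocarbonyl carbon, or a longer chain, would read in this assay.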